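Chloro in Place of Fluoro: What to Expect for Compound 4

The source may report more compounds than this note shows. Statements on the series, on what has been measured and on what is new or still open speak of the compounds shown alone.

Of the compounds shown here, three have been measured in an assay on CHO cells for binding affinity to Alpha-2C adrenergic receptor (Homo sapiens), read by radioligand binding; on this read-out lower numbers stand for stronger inhibition and higher numbers for weaker inhibition. Compound 2 `CSc1ccc(F)cc1NCC1=NCCN1` gives 115 nM in this assay. Compound 3 `CSc1ccc(Cl)cc1NCC1=NCCN1` gives 170 nM in this assay. The change between them is chloro in place of fluoro on an aromatic carbon, and it made the step of a 1.5-fold higher number from compound 2 to compound 3 (0.17 log units; within the scatter).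

Compound 1 `CS(=O)(=O)c1cc(F)ccc1NCC1=NCCN1` is known in this assay only as a limit, < 5020 nM, and not as an exact number. How the core of compound 1 differs from the core of compound 2 is not broken down here.

Compound 4 `CS(=O)(=O)c1cc(Cl)ccc1NCC1=NCCN1` has not yet been measured. It differs from compound 1 by chloro in place of fluoro on an aromatic carbon. Among the measured compounds shown here, this is the same kind of change as the one from compound 2 to compound 3, but the surroundings differ: in compound 1 the swapped position is meta to a methylsulfonyl group and para to a group of 7 heavy atoms, whereas in compound 2 it is meta to a group of 7 heavy atoms and para to a methylsulfanyl group.

Given that the step from compound 2 to compound 3 lay within the scatter, the step expected for compound 4 is a step that the limit leaves unreadable from compound 1 to compound 4. Because compound 1 is known only through the limit (the limit of < 5020 nM in this assay, at which 1 of the 3 values shown sits), compound 4 may likewise come back as a limit. The estimated value of compound 4 in this assay is 2500 nM, with a range from 600 nM to 5000 nM expected.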

Compound 4, inhibition constant: 3980 nM
The estimate for compound 4 lay 1.6-fold (0.20 log units) below the measured number; the measured number falls inside the stated range.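

Chloro in place of fluoro cannot be given a size between compound 1 and compound 4, because compound 1 is known in this assay only as a limit: the limit of < 5020 nM in this assay, at which 1 of the 4 values shown sits.

The compounds shown leave open whether this swap changes the number at all when a methylsulfonyl group is present, as in compound 1 and compound 4, instead of the methylsulfanyl group of compound 2 and compound 3.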